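The source may report more compounds than this note shows. Statements on the series, on what has been measured and on what is new or still open speak of the compounds shown alone.

Compound 1, `COc1ccc([C@@H](CC(=O)O)NC(=O)[C@@H]2CCN2S(=O)(=O)c2cc(Cl)cc(Cl)c2)cc1`: 0.39 nM; 0.49 nM (2 entries)
Compound 2, `O=C(O)C[C@@H](NC(=O)[C@@H]1CCN1S(=O)(=O)c1cc(Cl)cc(Cl)c1)c1ccc(OC(F)F)cc1`: 1.3 nM
Compound 3, `O=C(O)C[C@@H](NC(=O)[C@@H]1CCN1S(=O)(=O)c1cc(Cl)cc(Cl)c1)c1ccc(Cl)c(F)c1`: 11 nM

Of the compounds shown here, three sharing one core have been tested in an assay on RPMI-8866 cells for inhibition of integrin alpha-4/beta-1 (Homo sapiens); on this read-out higher numbers stand for weaker inhibition and lower numbers for stronger inhibition. Compound 1 has been run more than once, and the repeat entries the several entries of compound 1 in this assay, 0.39 nM; 0.49 nM (2 entries) sit close together. Compound 2 gives 1.3 nM, and compound 3 gives 11 nM, the highest number of the set. For the measured compounds named here, the one single-point step among them is an 8.5-fold higher number from compound 2 to compound 3 (0.93 log units; beyond the scatter), which moves the number well beyond the scatter.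

Compound 4, `COc1ccc([C@@H](CC(=O)O)NC(=O)[C@@H]2CCN2S(=O)(=O)c2cc(Cl)cc(Cl)c2)cn1`, is not yet measured. Its difference from compound 3 is 6-methoxypyridin-3-yl in place of 4-chloro-3-fluorophenyl on a saturated chain carbon bound to an amide-type nitrogen and a saturated chain carbon. The change puts a methoxy-bearing six-membered aromatic ring back in the place where compound 1 and compound 2 carry alkoxy-substituted phenyl groups, so the relevant comparison is the step from compound 2 to compound 3, which ran in the opposite direction and was of modest size. Reversing it, compound 4 is expected to come in at 1.2 nM, within a range of 0.35 nM to 4.5 nM. The expected step is therefore a 9.2-fold lower number from compound 3 to compound 4 (0.96 log units; beyond the scatter), a lower number beyond the scatter, though the ring nitrogen makes the size of this expected step uncertain.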

Compound 4, half-maximal inhibitory concentration: 3 nM
Compound 4: the middle estimate sits 2.5-fold (0.40 log units) below what was measured; measured number inside the range.
By their numbers in this assay, from the lowest: compound 2; then compound 4; then compound 3.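

In this assay, putting 6-methoxypyridin-3-yl in place of 4-chloro-3-fluorophenyl on the saturated chain carbon gives a 3.7-fold lower number from compound 3 to compound 4 (0.56 log units; beyond the scatter), which shows that a ring with a hetero atom can bring the number down at this place. The recovery is only partial, as replacing 4-(difluoromethoxy)phenyl with the same ring gives a 2.3-fold higher number from compound 2 to compound 4 (0.36 log units; beyond the scatter), and compound 4, at 3 nM, also differs only by the ring nitrogen from compound 1, which gives 0.39 nM; 0.49 nM (2 entries), both entries lower than the number of compound 4. Nothing measured here gives a reason for either step.

The compounds shown leave open how the number would move with an ethoxy group or a dimethylamino group in place of the methoxy group of 6-methoxypyridin-3-yl. They also leave open whether a second ring nitrogen, as in a methoxypyrimidinyl group, would carry the number further from that of compound 1 or whether a chlorine or fluorine on the pyridine ring would bring it closer.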